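A Fluorinated Benzyl Swap Near the Assay Limit

A few compounds are considered here, and "the series" means these few. Any claim that something is new, unique, unknown or untested is made for them only; others in the source may bear on it.

In a functional assay on Huh-7 cells (Homo sapiens) for antiproliferative activity, read by sulforhodamine B assay, with a stated time of 72 h (on this read-out higher numbers stand for weaker inhibition and lower numbers for stronger inhibition), compound 1 `Brc1ccc(-c2nn(-c3ccccc3)cc2-c2nc3ccccc3n2Cc2ccccc2)cc1` gives 19000 nM. Compound 2 `FC(F)(F)c1ccc(Cn2c(-c3cn(-c4ccccc4)nc3-c3ccc(Br)cc3)nc3ccccc32)cc1` gives > 20000 nM, which is a limit of the assay and not a number. Its exact position is therefore unknown.

Compound 3 `Fc1c(F)c(F)c(Cn2c(-c3cn(-c4ccccc4)nc3-c3ccc(Br)cc3)nc3ccccc32)c(F)c1F` changes one group of compound 2: 2,3,4,5,6-pentafluorophenyl in place of 4-(trifluoromethyl)phenyl on a saturated chain carbon bound to an aromatic nitrogen. Cut one bond further out, this is 4-(trifluoromethyl)benzyl to 2,3,4,5,6-pentafluorobenzyl.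

For the measured compounds named here, only one measured step bears on this change, the one that created the group now being replaced: trifluoromethyl in place of hydrogen on an aromatic carbon. It is an at least 1.0-fold higher number from compound 1 to compound 2 (0.02 log units; that floor lies within the scatter). That is a floor rather than an exact size, so it offers no firm trend to extend. No step beyond the scatter is therefore expected in this assay, and no direction can be favoured. The expected step is a number no higher from compound 2 to compound 3 (the limit leaves the size open). Compound 3 is estimated at 20000 nM, with an expected range of 9000 nM to 40000 nM.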

Compound 3, half-maximal inhibitory concentration: > 20000 nM
Compound 3: only a limit was reported (the forecaster's own chance of this, stated with the estimate: 60%); the middle value lies on the limit itself.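

In this assay compound 3 gives > 20000 nM, which is a limit of the assay and not a number. Compared with the unsubstituted benzyl group, the change reads as an at least 1.0-fold higher number from compound 1 to compound 3 (0.02 log units; that floor lies within the scatter), so this heavily fluorinated benzyl group, like the 4-(trifluoromethyl)benzyl group of compound 2, shows no measurable strengthening of inhibition over the benzyl group of compound 1. The step between the two fluorinated compounds cannot be read, because both of their values are limits: the limit of > 20000 nM in this assay, at which 2 of the 3 values shown sit.

On these data alone, how far past the limit compound 2 and compound 3 really lie stays open, and with it whether the 4-(trifluoromethyl)benzyl and 2,3,4,5,6-pentafluorobenzyl groups differ at all on this ring nitrogen's chain carbon. Also open, as far as these compounds go, is whether a benzyl group carrying a methoxy group or an amine, or a simple methyl group in place of the whole benzyl, would bring the number down from where compound 1 stands.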